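This account rests on a few compounds, and the source may have more. Where it says the series, first, only, none or still open, it means among the compounds named here.

Compound 3, whose structure is `Cc1nc(-c2ccc(Cl)cc2)ccc1C(=O)N/N=C/c1ccc(O)cc1`, was tested in an ADME assay on WI-38 cells (Homo sapiens) for cytotoxicity, read by colorimetric assay and crystal violet staining, with a stated time of 24 h (on this read-out higher numbers stand for weaker inhibition and lower numbers for stronger inhibition), where compound 3 gives 500 ug/mL. This is the highest number among the three compounds measured, and so the weakest inhibition: compound 1, with structure `COc1ccc(OC)c(/C=N/NC(=O)c2ccc(-c3cccc(Cl)c3)nc2C)c1`, gives 188 ug/mL in this assay, and compound 2, with structure `COc1cc(/C=N/NC(=O)c2ccc(-c3ccc(Cl)cc3)nc2C)cc(OC)c1OC`, gives 41.1 ug/mL in this assay, both of them beyond the usual scatter from compound 3.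

Compound 4, with structure `COc1cccc(/C=N/NC(=O)c2ccc(-c3ccc(Cl)cc3)nc2C)c1O`, has not yet been measured. It differs from compound 3 in one place: 2-hydroxy-3-methoxyphenyl in place of 4-hydroxyphenyl on a carbon with a double bond to nitrogen. Going by the values given here, no step between measured compounds follows this exact change, so the expectation rests on the spread of the measured values alone. A modest move towards stronger inhibition is expected, since the two compounds with more substituted rings on that carbon, compound 1 at 188 ug/mL and compound 2 at 41.1 ug/mL, both give lower numbers than compound 3. The expected step in this assay is a 3.1-fold lower number from compound 3 to compound 4 (0.49 log units; beyond the scatter). Compound 4 is therefore estimated at 160 ug/mL, with a likely range from 60 ug/mL to 450 ug/mL.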

Compound 4, half-maximal inhibitory concentration: 500 ug/mL
Compound 4: middle estimate off by 3.1-fold (0.49 log units), on the low side, outside the stated range (above it).
By their numbers in this assay, from the lowest: compound 2; then compound 1; then compounds 3 and 4 (each within the scatter of the next).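

Placing 2-hydroxy-3-methoxyphenyl in place of 4-hydroxyphenyl on the carbon with a double bond to nitrogen gives no change at the digits printed from compound 3 to compound 4 (within the scatter) in this assay, so a larger ring with an added methoxy group does not by itself lower the number at this position. Differing from compound 4 only in the ring on that carbon, compound 2, whose ring carries methoxy groups but no hydroxy group, gives 41.1 ug/mL, so ring substitution alone does not account for the lower number. No measurement here explains why these rings read as they do.

No pair shown changes the hydroxy or methoxy groups one at a time, so their separate contributions remain open. Also open, from the compounds shown here alone, is how a plain phenyl, or a ring carrying an amine or a carboxylic acid, would read at this place.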